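The compounds below may be only part of what the source reports. "The series", "measured", "known", "first", "only" and "open" are said of these compounds alone.

Of the compounds shown here, three built on one shared core have been tested in a functional assay on the whole organism (strain Wistar) for inhibition, with Rattus norvegicus as the target, read by paw edema, with a stated time of 2 h, at a dose of 30 mg/kg; on this read-out higher numbers stand for more inhibition at the one dose given (going by the name of the read-out) and lower numbers for less inhibition. Compound 1 `COc1ccc2sc(NC(=O)CN3CCN(c4ccccc4)CC3)nc2c1` gives 21.7% in this assay. Compound 2 `COc1ccc2sc(NC(=O)CN3CCCNCC3)nc2c1` carries a different group at the far end of the chain; the difference between the two cores is not broken down here. In this assay compound 2 gives 17.4%, and the gap between compound 2 and compound 1 lies within the usual scatter, so the two cannot be told apart on this measure. Compound 3 `O=C(CN1CCN(c2ccccc2)CC1)Nc1nc2cc([N+](=O)[O-])ccc2s1` differs from compound 1 in a single place: nitro in place of methoxy on an aromatic carbon In this assay compound 3 gives 34.8%, which is a number 13.1 percentage points higher from compound 1 to compound 3 (beyond the scatter) and stands beyond the scatter. Compound 4 `O=C(CN1CCCNCC1)Nc1nc2cc([N+](=O)[O-])ccc2s1` has not yet been measured. It stands to compound 2 as compound 3 stands to compound 1, since it is made from compound 2 by the same change at the same place: nitro in place of methoxy on an aromatic carbon Among the compounds shown this change occurs twice in all, and only one of the two occurrences has been measured, so any expectation rests on a single step. A similar step is expected here, a number 12.6 percentage points higher from compound 2 to compound 4 (beyond the scatter), because the same change gave a number 13.1 percentage points higher from compound 1 to compound 3 (beyond the scatter) on the other core. On that basis compound 4 is estimated to reach about 30% in this assay. Going by the values given here, for compound 4 the likely span is estimated to run from 19% up to 41%, the width reflecting that only one earlier example of the change exists.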

Compound 4, a percentage reported as inhibition, in the whole organism at one dose (the size of the read-out at that dose, not a potency): 17.4%
For compound 4 the middle estimate is 12.6 percentage points above the measured one, outside the stated range (below it).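

On the second core, nitro in place of methoxy gives, in this assay, no change at the digits printed from compound 2 to compound 4 (within the scatter). Set beside the earlier step, this does not show that the core alters what the change does, since the gap between the two steps stays within what two such steps can scatter: the same change on two cores in this assay, a number 13.1 percentage points higher (beyond the scatter) from compound 1 to compound 3 and no change at the digits printed (within the scatter) from compound 2 to compound 4, 13.1 percentage points apart, within the scatter of two such steps The series therefore shows neither that the gain seen on the first core carries over to the second nor that it is lost there; with only two pairs, read at a single dose and a single time, the question stays undecided, and the numbers give no reason for either outcome.

The compounds shown carry only methoxy and nitro on this aromatic carbon, so it remains open how other groups in that place, such as a chlorine atom, an amine or a trifluoromethyl group, would read on either core, and whether a third pair would side with the first step or the second. Also open, as far as these compounds go, is what a longer chain at the amide carbonyl would do to the size of this change.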